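Adding chloro to a compound at the assay limit

The source may hold more compounds than are shown below. What is called first, only, known or untested is meant among the compounds shown, and "the series" means these compounds.

Compound 1 `CCOC(=O)c1c(-c2cc(F)cc(OC)c2)[nH]c2cc(OC)ccc2c1=O` gives > 22000 nM as a limit
Compound 2 `CCOC(=O)c1c(-c2ccccc2)[nH]c2cc(OC)ccc2c1=O` gives > 22000 nM as a limit
Compound 3 `CCOC(=O)c1c(-c2cccc(OCC)c2)[nH]c2cc(OC)ccc2c1=O` gives > 22000 nM as a limit

These readings come from an ADME assay on HEK293 cells (Homo sapiens) for cytotoxicity, read by luminescence, with a stated time of 72 h (a higher number here means that more compound is needed for the effect, a lower number that less compound is needed), and none of them is an exact number. Compound 1 stands with the other two: the limit of > 22000 nM in this assay, at which 3 of the 3 values shown sit, so it offers a limit and not a number as a starting point.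

Compound 4 `CCOC(=O)c1c(-c2cc(F)cc(OC)c2)[nH]c2cc(OC)c(Cl)cc2c1=O` keeps the core of compound 1 and differs in one place, with chloro in place of hydrogen on an aromatic carbon. Going by the values given here, no measured step makes this change. The nearest evidence is three changes elsewhere in the structure: a step that the two limits leave unreadable from compound 1 to compound 2, a step that the two limits leave unreadable from compound 1 to compound 3 and a step that the two limits leave unreadable from compound 2 to compound 3. None of these has a readable size, so they offer only weak guidance.

No step beyond the usual scatter is expected in this assay, and no direction can be favoured. The expected step is a step that the limit leaves unreadable from compound 1 to compound 4 and the assay may well report a limit again. For compound 4 the estimated value is 25000 nM with an expected range from 10000 nM to 50000 nM in this estimate.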

Compound 4, half-maximal effective concentration: > 22000 nM
Compound 4 ended at the assay's limit; the forecaster's own chance of this, stated with the estimate: 80%; the middle value is on the limit's open side.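

Compound 1 and compound 4 both give only a limit in this assay, so the step from adding chloro cannot be read: the limit of > 22000 nM in this assay, at which 4 of the 4 values shown sit.

The compounds shown leave open how much of any of them is needed for the effect, and whether chloro changes that amount at all.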